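Swapping the naphthyl for a sulfur-bearing phenyl

A few compounds are considered here, and "the series" means these few. Any claim that something is new, unique, unknown or untested is made for them only; others in the source may bear on it.

Of the compounds shown here, three on a shared core have been measured in a functional assay on HeLa cells (Homo sapiens) for cytotoxicity, read by MTT assay, with a stated time of 48 h; on this read-out higher numbers stand for weaker inhibition and lower numbers for stronger inhibition. Compound 1 `Cc1nc2c3ccccc3ccc2c2nc3c(ccc4ccccc43)c(-c3cccc([N+](=O)[O-])c3)c12` gives 50700 nM, compound 2 `Cc1nc2c3ccccc3ccc2c2nc3c(ccc4ccccc43)c(-c3cccnc3)c12` gives 3860 nM, and compound 3 `Cc1nc2c3ccccc3ccc2c2nc3c(ccc4ccccc43)c(-c3cccc4ccccc34)c12` gives 14900 nM, which leaves compound 3 second highest of the three, between the other two. The change to compound 4 `Cc1nc2c3ccccc3ccc2c2nc3c(ccc4ccccc43)c(-c3ccccc3S)c12` is 2-sulfanylphenyl in place of naphthalen-1-yl on an aromatic carbon. Within the data shown here, two measured steps bear on exchanging this aryl group: a 3.4-fold lower number from compound 1 to compound 3 (0.53 log units; beyond the scatter) and a 3.9-fold higher number from compound 2 to compound 3 (0.59 log units; beyond the scatter), while a 13-fold lower number from compound 1 to compound 2 (1.12 log units; beyond the scatter) shows the pyridin-3-yl group giving the lowest number. Among the measured compounds shown here, a single six-membered ring bearing a sulfur has no precedent here, so the expected step for compound 4 is a 1.9-fold lower number from compound 3 to compound 4 (0.27 log units; within the scatter), most likely within the scatter. Compound 4 is expected to give 8000 nM, with a range from 2000 nM to 35000 nM.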

Compound 4, half-maximal inhibitory concentration: 3190 nM
The estimate for compound 4 lay 2.5-fold (0.40 log units) above the measured number, and the stated range covers the measured number.
By their numbers in this assay, from the lowest: compounds 4 and 2 (each within the scatter of the next); then compound 3; then compound 1.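

In this assay, a single ring, 2-sulfanylphenyl, gives a lower number than the two-ring naphthalen-1-yl (a 4.7-fold lower number from compound 3 to compound 4 (0.67 log units; beyond the scatter)), so this position does not need the larger aryl group to reach a low number. Compound 4 also sits within the scatter of the pyridin-3-yl compound (a 1.2-fold lower number from compound 2 to compound 4 (0.08 log units; within the scatter)) and far below the 3-nitrophenyl compound (a 16-fold lower number from compound 1 to compound 4 (1.20 log units; beyond the scatter)), so single rings at this position can give very different numbers. Nothing measured here explains these differences. As far as these compounds go, how plain phenyl or 2-hydroxyphenyl would compare remains open, and with it whether the sulfur itself matters.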